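Methyl for Hydrogen on the Chain Carbon of Compound 3

This account rests on a few compounds, and the source may have more. Where it says the series, first, only, none or still open, it means among the compounds named here.

Measured compounds:
Compound 1 `C/N=C(/NC#N)NCCCCCCn1nc(-c2ccccc2)ccc1=O` gives 31.7% in a functional assay on the whole organism with Rattus norvegicus as the target, at a dose of 100 mg/kg; on this read-out lower numbers stand for less inhibition and higher numbers for more inhibition at the one dose given (going by the name of the read-out).
Compound 2 `CC/N=C(/NC#N)NCCCCCCn1nc(-c2ccccc2)ccc1=O` gives 29.1% in this assay.
Compound 3 `C/N=C(/NC#N)NCCCn1nc(-c2ccccc2)c(C)cc1=O` gives 17.2% in this assay.

Compound 2 differs from compound 1 by one change, (methyl in place of hydrogen on a saturated chain carbon bound to a double-bonded nitrogen), and the step it made was a number 2.6 percentage points lower from compound 1 to compound 2 (within the scatter). Compound 4 `CC/N=C(/NC#N)NCCCn1nc(-c2ccccc2)c(C)cc1=O` is not yet measured; it differs from compound 3 by methyl in place of hydrogen on a saturated chain carbon bound to a double-bonded nitrogen, the same change at the same place. The difference between the core of compound 3 and the core of compound 1 is not broken down here. Because compound 1 to compound 2 moved only a number 2.6 percentage points lower from compound 1 to compound 2 (within the scatter), compound 4 is expected to stay close to compound 3, with an expected step of a number 1.7 percentage points lower from compound 3 to compound 4 (within the scatter). The estimate for compound 4 is 15.5%, between 5% and 28%.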

Compound 4, a percentage reported as inhibition, in the whole organism at one dose (the size of the read-out at that dose, not a potency): 0.2%
Compound 4: the middle estimate sits 15.3 percentage points above what was measured, and the stated range ends above it.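

In this assay, methyl in place of hydrogen on a saturated chain carbon bound to a double-bonded nitrogen gave a number 17 percentage points lower from compound 3 to compound 4 (beyond the scatter). The step therefore did not carry over unchanged from one core to the other: the same change on two cores in this assay, a number 2.6 percentage points lower (within the scatter) from compound 1 to compound 2 and a number 17 percentage points lower (beyond the scatter) from compound 3 to compound 4, 14.4 percentage points apart, beyond the scatter of two such steps This shows that the same change can give steps of different size in this series, but it does not show which difference between the two cores goes with the larger step, and two pairs set no rule for other cores.

The compounds shown leave open how a longer chain, such as propyl, would read at this place on either core. They also leave open what the same change does on a core differing from the core of compound 1 in one place only.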